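The source may report more compounds than this note shows. Statements on the series, on what has been measured and on what is new or still open speak of the compounds shown alone.

Compound 1 `N#Cc1cnc(NCc2cnccc2C(F)(F)F)cc1NC[C@H]1CC[C@H](O)CC1`: 2000 nM
Compound 2 `CC1(C)C[C@H](Nc2cc(NCc3cnccc3C(F)(F)F)ncc2C#N)CC(C)(C)[C@H]1O`: 500 nM
Compound 3 `CC1(C)[C@H](O)C[C@H]1Nc1nc(NCc2cnccc2C(F)(F)F)ncc1C#N`: 4500 nM

Of the compounds shown here, three have been measured in an assay on isolated protein for inhibition of protein kinase C delta type (Homo sapiens), read by TR-FRET, with a stated time of 2 h; a lower number here means a stronger inhibitor, a higher number a weaker inhibitor. Among them compound 1 holds the second-highest number. Compound 3 stands nearest to it, with a higher number, while compound 2 shows the lowest number of the three and lies furthest from compound 1; both of these gaps fall beyond the usual scatter of repeated measurements.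

Compound 4 `CC1(C)[C@@H](C(N)=O)C[C@H]1Nc1cc(NCc2cnccc2C(F)(F)F)ncc1C#N` has not yet been measured in this assay. Set against compound 1, the change is 3-carbamoyl-2,2-dimethylcyclobutyl in place of (4-hydroxycyclohexyl)methyl on a nitrogen on an aromatic ring. Going by the values given here, compound 2 and compound 3 also carry a ring bound directly to that nitrogen, and their numbers fall on either side of compound 1, so the values at hand give no consistent direction for such a change; a carbamoyl group appears in none of the measured compounds. The expected step of no change at the digits printed from compound 1 to compound 4 (within the scatter) is therefore small, with no clear direction beyond the scatter. The estimate for compound 4 is 2000 nM, with a range from 500 nM to 8000 nM.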

Compound 4, half-maximal inhibitory concentration: 160 nM
Estimate against measurement, compound 4: 13-fold (1.10 log units) above, and the stated range ends above it.
By their numbers in this assay, from the lowest: compound 4; then compound 2; then compound 1; then compound 3.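

In this assay, 3-carbamoyl-2,2-dimethylcyclobutyl in place of (4-hydroxycyclohexyl)methyl on a nitrogen on an aromatic ring gives a 13-fold lower number from compound 1 to compound 4 (1.10 log units; beyond the scatter), a large step. Going by these compounds alone, this shows that the number is sensitive to the group at this nitrogen, and that a carbamoyl group can stand there where the earlier compounds all carried a hydroxyl, with the counted hydrogen-bond donors and acceptors of the group unchanged. Nothing at hand explains the step.

The change alters the ring size, the methylene link, the two methyl groups and the terminal group all at once, so the compounds shown cannot assign the step to any one of them. As far as these compounds go, it also remains open how a carboxylic acid or a primary amine in place of the carbamoyl would read.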